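Swapping a Dibromohydroxyphenyl for a Fluorohydroxyphenyl

A few compounds are considered here, and "the series" means these few. Any claim that something is new, unique, unknown or untested is made for them only; others in the source may bear on it.

Of the compounds shown here, three sharing one core have been tested in a functional assay on U-87MG ATCC cells (Homo sapiens) for cytotoxicity, read by MTT assay, with a stated time of 72 h; a lower number here means a stronger inhibitor, a higher number a weaker inhibitor. Compound 1 `CN(C)CCn1cnnc1-c1cc(Oc2ccc(NC(=O)N/N=C/c3c(Cl)cccc3Cl)cc2F)ccn1` reaches only the limit of the assay, giving > 100000 nM. Compound 2 `COc1ccc(/C=N/NC(=O)Nc2ccc(Oc3ccnc(-c4nncn4CCN(C)C)c3)c(F)c2)c(OC)c1OC` gives a readable number, 7650 nM. Compound 3 `CN(C)CCn1cnnc1-c1cc(Oc2ccc(NC(=O)N/N=C/c3cc(Br)c(O)c(Br)c3)cc2F)ccn1` again reaches only the limit, at > 100000 nM. Compound 3 therefore stands at the limit of > 100000 nM in this assay, at which 2 of the 3 values shown sit, with no number of its own.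

The readable steps show how much the group on the carbon with a double bond to nitrogen matters: an at least 13-fold lower number from compound 1 to compound 2 (1.11 log units; beyond the scatter), and an at least 13-fold higher number from compound 2 to compound 3 (1.11 log units; beyond the scatter). The step that the two limits leave unreadable from compound 1 to compound 3 cannot be sized, as both ends are limits.

Compound 4 `CN(C)CCn1cnnc1-c1cc(Oc2ccc(NC(=O)N/N=C/c3ccc(O)c(F)c3)cc2F)ccn1` differs from compound 3 in one place: 3-fluoro-4-hydroxyphenyl in place of 3,5-dibromo-4-hydroxyphenyl on a carbon with a double bond to nitrogen. For the measured compounds named here, no measured step covers this exact exchange. Going by the values given here, the two readable steps show only that replacing this group can shift the result by a large amount in either direction. Because compound 3 stands at the limit of > 100000 nM, a move toward stronger inhibition would become readable, while a move toward weaker inhibition would stay hidden behind the same limit.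

Compound 4 is expected near 60000 nM, between 15000 nM and 200000 nM. This estimate for compound 4 corresponds to an expected step of an at least 1.6-fold lower number from compound 3 to compound 4 (0.22 log units; that floor lies within the scatter).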

Compound 4, half-maximal inhibitory concentration: > 100000 nM
Compound 4: only a limit was reported; the forecaster's own chance of this, stated with the estimate: 55%; middle value at least 1.6-fold (0.22 log units) from the limit.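

In this assay, compound 4 gives > 100000 nM, which is a limit and not a number. The 3-fluoro-4-hydroxyphenyl group therefore joins 3,5-dibromo-4-hydroxyphenyl and 2,6-dichlorophenyl on the carbon with a double bond to nitrogen as a group with no readable result, so exchanging the bromines for a fluorine brings no measurable gain in this assay: the limit of > 100000 nM in this assay, at which 3 of the 4 values shown sit. For the compounds shown here, the one step that can be read is an at least 13-fold higher number from compound 2 to compound 4 (1.11 log units; beyond the scatter), with 2,3,4-trimethoxyphenyl still the only group here that gives a number, while the steps among the three limit compounds cannot be read, as both ends are limits.

Compound 1, compound 3 and compound 4 may lie close together or far apart beyond the limit, and nothing shown separates them. Also open, on these data alone, is whether the readable result of compound 2 rests on its methoxy groups, and what a plain phenyl, a 4-methoxyphenyl or a carboxylic acid on this carbon would give.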